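This account rests on a few compounds, and the source may have more. Where it says the series, first, only, none or still open, it means among the compounds named here.

Compound 1 `CN(C)c1ncnc2c1ncn2Cc1c(F)cccc1Cl` carries a dimethylamino group on the shared core and a benzyl arm bearing both fluorine and chlorine; in a functional assay on the whole organism with Rattus norvegicus as the target, in the maximal electroshock model (on this read-out higher numbers stand for an effect only at larger amounts of compound and lower numbers for an effect already at smaller amounts), compound 1 gives 5 mg/kg. Compound 2 `Fc1ccccc1Cn1cnc2c(N3CCC3)ncnc21` instead carries an azetidin-1-yl group and a benzyl arm with fluorine only. In this assay compound 2 reaches only a limit of the assay, > 50 mg/kg, which is the limit of > 50 mg/kg in this assay, at which 1 of the 2 values shown sits, so no exact number is known for it. Compound 3 `CN(C)c1ncnc2c1ncn2Cc1ccccc1F` differs from compound 2 by dimethylamino in place of azetidin-1-yl on an aromatic carbon. That is the group found in compound 1, whose dose of 5 mg/kg is the only firm point here. The expected step of an at least 3.3-fold lower number from compound 2 to compound 3 (0.52 log units; beyond the scatter) points toward lower doses. Compound 3 is therefore estimated at 15 mg/kg, between 4 mg/kg and 60 mg/kg.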

Compound 3, dose for half-maximal effect: 8.8 mg/kg
Beside the measured number, compound 3's estimate is 1.7-fold (0.23 log units) above it; measured number inside the range.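

In this assay, dimethylamino in place of azetidin-1-yl on this aromatic carbon gives an at least 5.6-fold lower number from compound 2 to compound 3 (0.75 log units; beyond the scatter), so this single change matters on this read-out. As far as these compounds go, compound 2 stands at a limit of the assay, so the true size of the step stays unknown: the limit of > 50 mg/kg in this assay, at which 1 of the 3 values shown sits. Hydrogen in place of chloro on the benzyl arm gives a 1.8-fold higher number from compound 1 to compound 3 (0.25 log units; within the scatter), so those two compounds cannot be told apart here. Open, from the compounds shown here alone, is how other amines at this place, such as pyrrolidin-1-yl, piperidin-1-yl or methylamino, would compare with dimethylamino.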